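Aryl hydrazone series: partition coefficient notes

The source may report more compounds than this note shows. Statements on the series, on what has been measured and on what is new or still open speak of the compounds shown alone.

Measured so far:
Compound 1 `O=C(COc1cccc2ccccc12)N/N=C/c1ccc(O)cc1` gives 3.73 in a physicochemical assay for lipophilicity, measured as octanol-water partition; a higher number here means a more lipophilic compound, a lower number a more polar compound.
Compound 2 `C/C(=N\NC(=O)COc1cccc2ccccc12)c1cccc([N+](=O)[O-])c1` gives 3.37 in this assay.

Compound 1 stands highest of the two numbers; its nearest neighbour is compound 2, which lies lower by a gap beyond the usual scatter. Among the measured compounds shown here, the two differ in more than one place, so no single step is drawn between them; only their values are compared.

Compound 3 `O=C(COc1cccc2ccccc12)N/N=C/c1ccccc1Br` is not yet measured in this assay. Relative to compound 1 the change is 2-bromophenyl in place of 4-hydroxyphenyl on a carbon with a double bond to nitrogen. The leaving group carries the only hydrogen-bond donor and acceptor counted in that part of the molecule; the entering group carries none. For the measured compounds named here, no measured pair in the set isolates this change, so the expectation rests on the structural difference alone. From compound 1 to compound 3 a step of a number 1.37 log units higher from compound 1 to compound 3 (beyond the scatter) is expected, upward and well beyond the scatter. Compound 3 is therefore estimated at 5.1, with a range from 4.6 to 5.6.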

Compound 3, partition coefficient: 4.81
Beside the measured number, compound 3's estimate is 0.29 log units above it; measured number inside the range.
By their numbers in this assay, from the lowest: compound 2; then compound 1; then compound 3.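

In this assay, among the compounds shown here, 2-bromophenyl in place of 4-hydroxyphenyl on a carbon with a double bond to nitrogen gives a number 1.08 log units higher from compound 1 to compound 3 (beyond the scatter) and this is the only single-place step, which shows that this position can carry a large change in the read-out. The counts shift with the change: the leaving group has 1 hydrogen-bond donor and 1 hydrogen-bond acceptor, the entering group has neither, and bromine stands where the group leaving held oxygen. No supporting measurement bears on why the step has this size.

For the compounds shown here, the single step cannot separate the removal of the hydroxy group from the arrival of bromine. An unsubstituted phenyl, a 4-bromophenyl or a 2-methoxyphenyl on the same carbon, with the rest of compound 1 unchanged, would divide the step into its parts.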